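A Halogen Swap at the Outer Aryl Ring

The source may report more compounds than this note shows. Statements on the series, on what has been measured and on what is new or still open speak of the compounds shown alone.

Compound 1 `C=C1C(=O)[C@]23C[C@@]1(O)CC[C@H]2c1ccc(OS(=O)(=O)c2ccc(C)cc2)c(C)c1[C@@H]3Cn1cc(-c2ccccn2)nn1` and compound 2 `C=C1C(=O)[C@]23C[C@@]1(O)CC[C@H]2c1ccc(OS(=O)(=O)c2ccc(C)cc2)c(C)c1[C@@H]3Cn1cc(-c2ccc(Br)cc2)nn1` share one core and differ only in the group carried at the far end: pyridin-2-yl in compound 1, 4-bromophenyl in compound 2. In a functional assay on SMMC-7721 cells (Homo sapiens) for cytotoxicity, read by MTT assay, with a stated time of 4 days (a lower number here means a stronger inhibitor, a higher number a weaker inhibitor), compound 1 gives 2830 nM, and compound 2 gives 4320 nM. The step of a 1.5-fold higher number from compound 1 to compound 2 (0.18 log units; within the scatter) lies within the scatter, so the two cannot be told apart. Within the data shown here, of the two numbers so far, compound 2 holds the upper one, with compound 1 within the scatter of it. Compound 3 `C=C1C(=O)[C@]23C[C@@]1(O)CC[C@H]2c1ccc(OS(=O)(=O)c2ccc(C)cc2)c(C)c1[C@@H]3Cn1cc(-c2ccc(Cl)cc2)nn1` carries the change (chloro in place of bromo on an aromatic carbon). Among the measured compounds shown here, no measured step touches a halogen on this ring; the only known step, swapping the whole outer group, stayed within the scatter, so a change of one halogen for another is expected to matter even less. Compound 3 is therefore expected to stand close to compound 2, with a step of a 1.1-fold lower number from compound 2 to compound 3 (0.03 log units; within the scatter) not beyond the scatter. The estimate for compound 3 in this assay is 4000 nM, within 1800 nM to 9000 nM.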

Compound 3, half-maximal inhibitory concentration: 6180 nM
For compound 3 the middle estimate is 1.5-fold (0.19 log units) below the measured one; low and high end bracket the measured number.
By their numbers in this assay, from the lowest: compounds 1, 2 and 3 (each within the scatter of the next, the first and the last beyond it).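

The halogen on the outer ring can be exchanged with little consequence: with chloro in place of bromo, the result is a 1.4-fold higher number from compound 2 to compound 3 (0.16 log units; within the scatter), so the two compounds cannot be told apart in this assay. Among these compounds, compound 3 does give the first step in this short series to pass the scatter, with 4-chlorophenyl in place of pyridin-2-yl producing a 2.2-fold higher number from compound 1 to compound 3 (0.34 log units; beyond the scatter), although this difference is modest and the same exchange with 4-bromophenyl stayed within the scatter. Nothing available explains either step.

On these data alone, it remains open whether an unsubstituted phenyl would sit with the pyridin-2-yl compound or with the halogen-bearing pair, which would help separate the effect of the ring from that of the halogen. Also open, as far as these compounds go, is how a fluoro, methoxy or amino group would read at this same place on the ring.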